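Moving the branch one carbon out on the acrylamide

This account rests on a few compounds, and the source may have more. Where it says the series, first, only, none or still open, it means among the compounds named here.

Compound 2 `COc1cc(N(C)CCN(C)C)c(NC(=O)C=C(C)C)cc1Nc1nccc(-c2cn(C)c3ccccc23)n1` gives the highest number of the two measured in a functional assay on A549 cells (Homo sapiens) for antiproliferative activity, read by MTT assay, with a stated time of 72 h (a lower number here means a stronger inhibitor, a higher number a weaker inhibitor), namely 4100 nM. Its nearest neighbour, compound 1 `C/C=C\C(=O)Nc1cc(Nc2nccc(-c3cn(C)c4ccccc34)n2)c(OC)cc1N(C)CCN(C)C`, gives 660 nM in this assay. Among the measured compounds shown here, the only measured step, a 6.2-fold higher number from compound 1 to compound 2 (0.79 log units; beyond the scatter), shows that adding a second methyl on the alkene weakened the compound. Compound 3 `COc1cc(N(C)CCN(C)C)c(NC(=O)/C=C\C(C)C)cc1Nc1nccc(-c2cn(C)c3ccccc23)n1` differs from compound 2 by 3-methylbut-1-en-1-yl in place of 2-methylprop-1-en-1-yl on a carbonyl carbon, so the alkene again carries a single substituent, as in compound 1. Compound 3 is therefore expected to recover part of that loss, a step of a 2.7-fold lower number from compound 2 to compound 3 (0.44 log units; beyond the scatter), giving an estimated 1500 nM with a range from 500 nM to 5000 nM.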

Compound 3, half-maximal inhibitory concentration: 612 nM
For compound 3 the middle estimate is 2.5-fold (0.39 log units) above the measured one, and the stated range covers the measured number.
By their numbers in this assay, from the lowest: compounds 3 and 1 (each within the scatter of the next); then compound 2.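

In this assay the carbon count of the group alone does not set the number: 3-methylbut-1-en-1-yl has more heavy atoms than 2-methylprop-1-en-1-yl, yet the step is a 6.7-fold lower number from compound 2 to compound 3 (0.83 log units; beyond the scatter). With a single substituent on the same alkene end, isopropyl and methyl cannot be told apart, at a 1.1-fold lower number from compound 1 to compound 3 (0.03 log units; within the scatter). Nothing available explains these numbers. Going by these compounds, whether a bulkier tert-butyl group or a chain ending in a morpholine would hold the same level at this place stays open.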